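Methyl on the ring nitrogen of compound 2

This account rests on a few compounds, and the source may have more. Where it says the series, first, only, none or still open, it means among the compounds named here.

For the measured compounds named here, in a functional assay on the whole organism (strain Sprague-Dawley) for inhibition, with Rattus norvegicus as the target, with a stated time of 10 min (on this read-out higher numbers stand for an effect only at larger amounts of compound and lower numbers for an effect already at smaller amounts), compound 2 `CCOC(=O)c1cnc(-c2ccccc2OCC)[nH]c1=O` gives 2 mg/kg as the only exact number so far. Compound 1 `CCOC(=O)c1cnc(-c2ccccc2F)[nH]c1=O` is recorded at > 10 mg/kg and this is a limit of this assay rather than a number. Compound 3 `CCOC(=O)c1cnc(-c2ccccc2OCC)n(C)c1=O` carries methyl in place of hydrogen on an aromatic nitrogen and is still unmeasured. Going by the values given here, only one measured step can guide the forecast: ethoxy in place of fluoro on an aromatic carbon gave an at least 5.0-fold lower number from compound 1 to compound 2 (0.69 log units; beyond the scatter) at a different place in the molecule. That step shows that one small change can shift this assay clearly, but it gives no direction for this new change. A cautious expectation is a loss of effect, with an estimated 4.0-fold higher number from compound 2 to compound 3 (0.60 log units; beyond the scatter) toward a higher number. For compound 3 the expected value is 8 mg/kg within an estimated range of 2.5 mg/kg to 30 mg/kg in this assay.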

Compound 3, dose for 50% inhibition: > 40 mg/kg
Compound 3: only a limit was reported; the forecaster's own chance of this, stated with the estimate: 45%; middle value at least 5.0-fold (0.69 log units) from the limit.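

In this assay, putting methyl in place of the hydrogen on the aromatic nitrogen gives an at least 20-fold higher number from compound 2 to compound 3 (1.30 log units; beyond the scatter), a large loss of effect from a small change and the first sign that this position is highly sensitive, since compound 1 and compound 2 both keep this hydrogen and differ only on the other aromatic ring. The change at this nitrogen moves the number in the unfavourable direction, whereas the earlier step, at a different place, moved it the favourable way. Compound 3 is recorded only as a limit, so the full size of the loss stays unknown: the limit of > 40 mg/kg in this assay, at which 1 of the 3 values shown sits.

This single pair cannot separate the loss of the hydrogen from the arrival of the methyl, and it offers no measured cause for the drop. From the compounds shown here alone, how an ethyl group, a longer chain or a chain ending in an amine would behave on this nitrogen remains open.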